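Permeability notes: phenyl-linked series, trifluoromethyl removal

A few compounds are considered here, and "the series" means these few. Any claim that something is new, unique, unknown or untested is made for them only; others in the source may bear on it.

Measured compounds:
compound 1 `COc1cccc(CNCCCNc2ccnc3cc(Oc4ccccc4)ccc23)c1O`: 317 10^-6 cm/s
compound 2 `FC(F)(F)c1ccc(-c2ccc3c(NCCCNCc4ccco4)ccnc3c2)cc1`: 237 10^-6 cm/s
compound 3 `FC(F)(F)c1cc(-c2ccc3c(NCCCNCc4ccco4)ccnc3c2)cc(C(F)(F)F)c1`: 237 10^-6 cm/s

Three compounds of the series have been run in an ADME assay for permeability, using PAMPA, with a stated time of 30 min, at pH 7.4; a lower number here means that the compound crosses the layer more slowly, a higher number that the compound crosses the layer faster. Compound 2 `FC(F)(F)c1ccc(-c2ccc3c(NCCCNCc4ccco4)ccnc3c2)cc1` gives 237 10^-6 cm/s in this assay, and compound 3 `FC(F)(F)c1cc(-c2ccc3c(NCCCNCc4ccco4)ccnc3c2)cc(C(F)(F)F)c1` gives 237 10^-6 cm/s, so the two stand level at the digits shown. Compound 1 `COc1cccc(CNCCCNc2ccnc3cc(Oc4ccccc4)ccc23)c1O` gives 317 10^-6 cm/s, and its gap to compound 2 lies within the scatter, so the three numbers are not separated by this assay. Among the compounds with values here, no step between two measured compounds that differ in one place is available.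

Compound 4 `c1ccc(-c2ccc3c(NCCCNCc4ccco4)ccnc3c2)cc1` is not yet measured. It differs from compound 2 by hydrogen in place of trifluoromethyl on an aromatic carbon, the trifluoromethyl leaving and hydrogen entering on an aromatic carbon of a six-membered aromatic ring of carbon only; the same difference, cut one bond further out, reads 4-(trifluoromethyl)phenyl to phenyl. The three measured values sit in a narrow band, and the step from compound 2 to compound 3, which adds a second trifluoromethyl, shows no change at the digits printed. On that basis the step of a 1.0-fold higher number from compound 2 to compound 4 (0.01 log units; within the scatter) is expected to be small, with no direction beyond the scatter. Compound 4 is therefore estimated at 240 10^-6 cm/s in this assay, with a range from 140 10^-6 cm/s to 400 10^-6 cm/s.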

Compound 4, apparent permeability: 237 10^-6 cm/s
For compound 4 the middle estimate is 1.0-fold (0.01 log units) above the measured one; the measured number falls inside the stated range.
By their numbers in this assay, from the lowest: compounds 2, 3, 4 and 1 (each within the scatter of the next).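

In this assay, hydrogen in place of trifluoromethyl on an aromatic carbon, para to a large group, gives no change at the digits printed from compound 2 to compound 4 (within the scatter). Within the data shown here, this is the first reading of a single change at this position, and it shows that 4-(trifluoromethyl)phenyl and phenyl are not separated by this assay in this pair, a statement that holds for this one pair and this one position and makes no claim about a wider pattern. Nothing measured here bears on why the two compounds are not separated.

Among these compounds, still open is whether a different group on this same aromatic carbon, such as an amine, a carboxylic acid or a nitrile, would give a step beyond the scatter in this assay, since trifluoromethyl and hydrogen are the only two groups compared here. Also open, from the compounds shown here alone, is what a longer chain would do in place of the chain that compound 2 and compound 4 share, as the step above leaves that part of the structure unchanged.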